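Oxime series: aryl swap on the imine carbon

This account rests on a few compounds, and the source may have more. Where it says the series, first, only, none or still open, it means among the compounds named here.

Going by the values given here, compound 2 `O/N=C(\CCN1CCN(c2ccccn2)CC1)c1cc(F)cc(F)c1` gives the higher of the two numbers so far, 74% in a functional assay on HEK293 cells with D(4) dopamine receptor (Homo sapiens) as the target, read by FLIPR (on this read-out lower numbers stand for smaller maximal responses and higher numbers for larger maximal responses), with compound 1 `O/N=C(\CCN1CCN(c2ccccn2)CC1)c1ccc(Cl)cc1` lower at 46%; that one step, a number 28 percentage points higher from compound 1 to compound 2 (beyond the scatter), is the only measured step here. Compound 3 `Cc1cc(C)cc(/C(CCN2CCN(c3ccccn3)CC2)=N/O)c1` differs from compound 2 by 3,5-dimethylphenyl in place of 3,5-difluorophenyl on a carbon with a double bond to nitrogen. Among the compounds with values here, no measured step exchanges one 3,5-substituted aryl for another, so the lone step from compound 1 gives no direct guide. For compound 3 the expectation is a step within the scatter, a number 4 percentage points lower from compound 2 to compound 3 (within the scatter), and an estimated value of 70%, ranging from 50% to 90%.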

Compound 3, largest response reached (reported as efficacy), in percent of the reference or control that the assay uses: 55%
Estimate against measurement, compound 3: 15 percentage points above; measured number inside the range.
By their numbers in this assay, from the lowest: compounds 1 and 3 (each within the scatter of the next); then compound 2.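

Within this assay, this is the first measured exchange of one 3,5-substituted aryl for another on a carbon with a double bond to nitrogen, and a number 19 percentage points lower from compound 2 to compound 3 (beyond the scatter) shows that 3,5-substitution alone does not hold the number of compound 2. With a number 9 percentage points higher from compound 1 to compound 3 (within the scatter) the groups 3,5-dimethylphenyl and 4-chlorophenyl are not told apart, so among these three only 3,5-difluorophenyl stands out. Nothing at hand bears on why these groups read as they do.

Still open, from the compounds shown here alone, is how unsubstituted phenyl or 3,5-dichlorophenyl would read on this carbon. Also open, going by these compounds, is whether a longer chain to the piperazine-bearing part of the core would change the order.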